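Replacing Chloro with Methyl in Compound 2

This account rests on a few compounds, and the source may have more. Where it says the series, first, only, none or still open, it means among the compounds named here.

In a functional assay on KB cells (Homo sapiens) for inhibition (a lower number here means a stronger inhibitor, a higher number a weaker inhibitor), compound 1 `Nc1nc2cc(Cl)c(Cl)cc2n1Cc1ccccc1` gives 170000 nM. Compound 2 `Nc1nc2cc(Cl)c(Cl)cc2n1Cc1ccc(Cl)cc1` gives 45000 nM, and compound 3 `COc1ccc(Cn2c(N)nc3cc(Cl)c(Cl)cc32)cc1` gives 45000 nM. Compound 2 and compound 3 are thus level, together the lowest of the three numbers. Compound 4 `Cc1ccc(Cn2c(N)nc3cc(Cl)c(Cl)cc32)cc1` has not yet been measured. It differs from compound 2 by methyl in place of chloro on an aromatic carbon. Within the data shown here, three measured steps bear on this change: chloro in place of hydrogen gave a 3.8-fold lower number from compound 1 to compound 2 (0.58 log units; beyond the scatter), methoxy in place of hydrogen gave a 3.8-fold lower number from compound 1 to compound 3 (0.58 log units; beyond the scatter), and methoxy in place of chloro gave no change at the digits printed from compound 2 to compound 3 (within the scatter). No shift beyond the scatter is therefore expected in this assay. The estimated step is a 1.1-fold higher number from compound 2 to compound 4 (0.05 log units; within the scatter). The expected value for compound 4 is 50000 nM, with an estimated range of 22000 nM to 110000 nM.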

Compound 4, half-maximal inhibitory concentration: 50000 nM
Estimate against measurement, compound 4: no gap at the digits printed, and the stated range covers the measured number.
By their numbers in this assay, from the lowest: compounds 2, 3 and 4 (each within the scatter of the next); then compound 1.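

In this assay, methyl on this aromatic carbon, para to a large group, matches chloro and methoxy, giving a 1.1-fold higher number from compound 2 to compound 4 (0.05 log units; within the scatter) and a 1.1-fold higher number from compound 3 to compound 4 (0.05 log units; within the scatter). Set against hydrogen, it gives a 3.4-fold lower number from compound 1 to compound 4 (0.53 log units; beyond the scatter), so a third group now shares the modest gain over hydrogen at this place. Nothing available here explains why these three groups match.

From the compounds shown here alone, whether an amine, a carboxylic acid or a longer chain at this place would stay at the same level remains open. So does whether any group here could go well beyond this modest step from hydrogen.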